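A Ring Swap on the Amide Nitrogen and Expected Cytotoxicity

The source may report more compounds than this note shows. Statements on the series, on what has been measured and on what is new or still open speak of the compounds shown alone.

Compound 1 `O=C1OCc2cc(N(Cc3ccc(C4CCCCC4)cn3)C(=O)[C@H]3CCN3S(=O)(=O)c3c(F)c(F)c(F)c(F)c3F)ccc21` was tested in an ADME assay on MCF-10A cells (Homo sapiens) for cytotoxicity, with a stated time of 72 h (a higher number here means that more compound is needed for the effect, a lower number that less compound is needed), where compound 1 gives 4600 nM. Compound 2 `O=C(NO)c1ccc(N(Cc2ccc(C3CCCC3)cc2)C(=O)[C@H]2CCN2S(=O)(=O)c2c(F)c(F)c(F)c(F)c2F)cc1` carries a different group on the same amide-type nitrogen; in this assay compound 2 gives 7300 nM, a number that lies within the usual scatter of the number for compound 1, so the two cannot be told apart on this read-out. Compound 3 `O=C(NO)c1cc(F)c(N(Cc2ccc(C3CCOCC3)cc2)C(=O)[C@H]2CCN2S(=O)(=O)c2c(F)c(F)c(F)c(F)c2F)cc1O` has no result in this assay: for compound 3 the entry reads "not determined" (no result reported). Compound 4 `O=C([C@H]1CCN1S(=O)(=O)c1c(F)c(F)c(F)c(F)c1F)N(Cc1ccc(C2CCCCC2)cn1)c1ccc2c(=O)[nH]ccc2c1` has not yet been measured. It differs from compound 1 in one place: a group of 11 heavy atoms (9 carbon, 1 nitrogen, 1 oxygen; one six-membered aromatic ring of carbon only, one six-membered aromatic ring with 1 hetero atom) in place of a group of 10 heavy atoms (8 carbon, 2 oxygen; one five-membered non-aromatic ring with 1 hetero atom, one six-membered aromatic ring of carbon only), on an amide-type nitrogen. Going by the values given here, no measured pair in this set shows what such a change does in this assay, so nothing here points to a direction. With the two measured numbers close together and no comparison for this change, the step of a 1.1-fold higher number from compound 1 to compound 4 (0.04 log units; within the scatter) is expected to be small, within the scatter, in no particular direction. In this assay compound 4 is therefore expected to give about 5000 nM, with a plausible range from 1500 nM to 15000 nM.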

Compound 4, half-maximal effective concentration: 2700 nM
The estimate for compound 4 lay 1.9-fold (0.27 log units) above the measured number, within the range that was stated.
By their numbers in this assay, from the lowest: compounds 4, 1 and 2 (each within the scatter of the next, the first and the last beyond it).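

On the amide-type nitrogen, replacing the group with a five-membered non-aromatic ring by the group with a six-membered aromatic ring with 1 hetero atom gives, in this assay, a 1.7-fold lower number from compound 1 to compound 4 (0.23 log units; within the scatter), so compound 1 and compound 4 cannot be told apart. Going by these compounds alone, this is the first direct comparison in the set that differs in one place, and it shows that this change, which also takes the group from 0 hydrogen-bond donors to 1, does not shift the read-out beyond the usual scatter. No measurement shown here explains this result.

This single step cannot show whether other groups on the same nitrogen would also leave the number within the scatter. A benzene ring carrying an amine or a carboxylic acid, for example, remains an open case in this assay.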